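The source may report more compounds than this note shows. Statements on the series, on what has been measured and on what is new or still open speak of the compounds shown alone.

Compound 1 `CSc1ccc(-c2ccc(Cn3ccnc3)cc2)s1`: 35%
Compound 2 `CCC(c1ccc(-c2ccsc2Cl)cc1)n1ccnc1`: 85%

For the measured compounds named here, in an assay for inhibition of steroid 17-alpha-hydroxylase/17,20 lyase (Homo sapiens), using NADPH, tested at 2 uM (on this read-out higher numbers stand for a stronger effect at the one concentration tested and lower numbers for a weaker effect), compound 2 stands highest of the two numbers known; its nearest neighbour, compound 1, lies a long way lower, well beyond the usual scatter. Compound 3 `CCC(c1ccc(-c2ccc(SC)s2)cc1)n1ccnc1` is not yet measured. It arises from compound 2 by one change: 5-(methylsulfanyl)thiophen-2-yl in place of 2-chlorothiophen-3-yl on an aromatic carbon. Going by the values given here, with no measured pair showing this exact change, the step is expected to go downward by a moderate amount, since compound 1 gives only 35% in this assay. Compound 3 is therefore estimated at 60%, within 35% to 85%, a step of a number 25 percentage points lower from compound 2 to compound 3 (beyond the scatter).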

Compound 3, a percentage reported as inhibition, at one concentration (the size of the read-out at that concentration, not a potency): 3%
Estimate against measurement, compound 3: 57 percentage points above, outside the stated range (below it).
By their numbers in this assay, from the lowest: compound 3; then compound 1; then compound 2.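

In this assay, 5-(methylsulfanyl)thiophen-2-yl in place of 2-chlorothiophen-3-yl gives a number 82 percentage points lower from compound 2 to compound 3 (beyond the scatter), so the result at this position depends strongly on which thiophene group it carries. Ethyl in place of hydrogen on the saturated chain carbon gives a number 32 percentage points lower from compound 1 to compound 3 (beyond the scatter), so with this thiophene group the ethyl does not raise the number. Nothing at hand explains either drop.

The change alters the thiophene's point of attachment and its substituent together, so their separate contributions cannot be told apart. Going by these compounds, how an unsubstituted thiophen-2-yl or a 5-methoxythiophen-2-yl group would score remains open.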